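This account rests on a few compounds, and the source may have more. Where it says the series, first, only, none or still open, it means among the compounds named here.

Compound 1 `CCCCCCCCc1ccc(OCC(=O)COc2ccc3[nH]c(C(=O)O)cc3c2)cc1`: 8.4 ug/mL
Compound 2 `CCCCCCCCc1ccc(OCC(=O)COc2ccc3c(c2)cc(C(=O)O)n3CCCCCC)cc1`: < 1 ug/mL (a limit)

Within the data shown here, in a physicochemical assay for solubility, in phosphate buffer, at pH 7.4 (a lower number here means a less soluble compound, a higher number a more soluble compound), compound 1 gives 8.4 ug/mL, the only true number so far, so there is no other number to rank it against. Compound 2 gives < 1 ug/mL, which is a limit of the assay and not a number.

Compound 3 `CCCCCCCCc1ccc(OCC(=O)COc2ccc3c(c2)cc(C(=O)O)n3CC(=O)O)cc1` has not yet been measured. Its structural change is carboxymethyl in place of hydrogen on an aromatic nitrogen. Among the measured compounds shown here, one measured step bears on this change, because hexyl replaces the same hydrogen on the aromatic nitrogen: an at least 8.4-fold lower number from compound 1 to compound 2 (0.92 log units; beyond the scatter). The size of that step is only a bound, set by the limit of < 1 ug/mL in this assay, at which 1 of the 2 values shown sits. It also describes hexyl and not carboxymethyl, so it gives weak guidance here. Starting from compound 1 at 8.4 ug/mL, a repeat of that fall is not expected, and a modest rise in this assay is expected instead, with wide uncertainty. The expected change is a 2.4-fold higher number from compound 1 to compound 3 (0.38 log units; beyond the scatter). The estimate for compound 3 is 20 ug/mL, with an expected range of 4 ug/mL to 100 ug/mL.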

Compound 3, solubility: 8.1 ug/mL
For compound 3 the middle estimate is 2.5-fold (0.39 log units) above the measured one; measured number inside the range.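

In this assay, the aromatic nitrogen of the shared core takes carboxymethyl in place of hydrogen with no difference that stands out from the scatter, the step being a 1.0-fold lower number from compound 1 to compound 3 (0.02 log units; within the scatter); a group on this nitrogen therefore does not always come with the fall seen for hexyl. The two substituted compounds show that what the group is matters here, with carboxy in place of pentyl on the saturated chain carbon bound to the aromatic nitrogen giving an at least 8.1-fold higher number from compound 2 to compound 3 (0.90 log units; beyond the scatter). On these data alone, the true size of that step is unknown, as compound 2 stands at a limit of the assay and not at a number: the limit of < 1 ug/mL in this assay, at which 1 of the 3 values shown sits.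

Hexyl and carboxymethyl differ both in chain length and in the carboxy group at the chain end, so the compounds shown cannot tell these two features apart; a six-carbon chain ending in a carboxylic acid would do so. As far as these compounds go, it also stays open whether a small methyl group or a chain ending in an amine on this nitrogen would read like compound 3 or like compound 2.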